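Changing the aryl group on a shared core

The compounds below may be only part of what the source reports. "The series", "measured", "known", "first", "only" and "open" are said of these compounds alone.

Compound 1 `CC(C)[C@@H]1CC[C@@H](C)C[C@@]12N(C)C(=O)[C@@H]1[C@H]3C(=O)N(c4ccc(Cl)cc4)C(=O)[C@H]3ON12` gives 2000 ug/mL in a functional assay, read by spectrophotometry, with a stated time of 2 h; a lower number here means a stronger inhibitor, a higher number a weaker inhibitor. Compound 2 `COc1ccc(N2C(=O)[C@H]3[C@H](ON4[C@@H]3C(=O)N(C)[C@@]43C[C@H](C)CC[C@H]3C(C)C)C2=O)cc1` gives 480 ug/mL. Compound 3 `Cc1ccc(N2C(=O)[C@H]3[C@H](ON4[C@@H]3C(=O)N(C)[C@@]43C[C@H](C)CC[C@H]3C(C)C)C2=O)c(C)c1` gives 420 ug/mL.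

Compound 2 stands second highest of the three numbers: compound 1 is further off, as a 4.2-fold lower number from compound 1 to compound 2 (0.62 log units; beyond the scatter) shows, while compound 3 is nearest, with a 1.1-fold lower number from compound 2 to compound 3 (0.06 log units; within the scatter) lying within the scatter. Compound 4 `CC(C)[C@@H]1CC[C@@H](C)C[C@@]12N(C)C(=O)[C@@H]1[C@H]3C(=O)N(c4ccc5ccccc5c4)C(=O)[C@H]3ON12` differs from compound 2 in one place: naphthalen-2-yl in place of 4-methoxyphenyl on an amide-type nitrogen in a ring. Both measured steps bear on this, as both change the aryl group on the same nitrogen: one was modest, the other within the scatter. Within the data shown here, a naphthalen-2-yl group has no direct precedent here, so the expected step from compound 2 to compound 4 is small, estimated as a 1.2-fold lower number from compound 2 to compound 4 (0.08 log units; within the scatter). Compound 4 is therefore expected to give about 400 ug/mL, in the range 150 ug/mL to 1200 ug/mL.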

Compound 4, half-maximal inhibitory concentration: 2520 ug/mL
Estimate against measurement, compound 4: 6.3-fold (0.80 log units) below; the measured number lies above the stated range.
By their numbers in this assay, from the lowest: compounds 3 and 2 (each within the scatter of the next); then compounds 1 and 4 (each within the scatter of the next).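

On this nitrogen, the aryl group can raise the number as well as lower it: in this assay, naphthalen-2-yl, with its two aromatic rings, gives a 5.3-fold higher number from compound 2 to compound 4 (0.72 log units; beyond the scatter) and a 6.0-fold higher number from compound 3 to compound 4 (0.78 log units; beyond the scatter). Against the 4-chlorophenyl group the same change gives a 1.3-fold higher number from compound 1 to compound 4 (0.10 log units; within the scatter), so these two compounds stay level and both read well above compounds 2 and 3. No measurement here accounts for this split. Still open, going by these compounds, is how a ring that is not purely carbon, such as pyridin-3-yl, or a saturated ring, such as cyclohexyl, would read on this nitrogen.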